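Extending the ether chain of compound 3

This account rests on a few compounds, and the source may have more. Where it says the series, first, only, none or still open, it means among the compounds named here.

Of the compounds shown here, three sharing one core have been tested in a functional assay on the whole organism (strain C57B/6) with Mus musculus as the target, in the maximal electroshock model; a higher number here means that more compound is needed for the effect, a lower number that less compound is needed. Compound 1 `CCc1nncn1-c1ccc(OCc2ccc(Cl)cc2)cc1` gives 19.7 mg/kg, and compound 2 `CCc1nncn1-c1ccc(OCc2cccc(Cl)c2)cc1` gives 27.4 mg/kg, so that a 1.4-fold higher number from compound 1 to compound 2 (0.14 log units; within the scatter). Compound 3 `CCCCCCCOc1ccc(-n2cnnc2CC)cc1` gives 8.3 mg/kg, the lowest number of the three: a 2.4-fold lower number from compound 1 to compound 3 (0.38 log units; beyond the scatter), and a 3.3-fold lower number from compound 2 to compound 3 (0.52 log units; beyond the scatter). Compound 4 `CCCCCCCCCCCCOc1ccc(-n2cnnc2CC)cc1` has not yet been measured. It differs from compound 3 by pentyl in place of hydrogen on a saturated chain carbon, seven bonds along the chain from an oxygen on an aromatic ring, the change sitting on a saturated chain carbon, seven bonds along the chain from an oxygen on an aromatic ring. Going by the values given here, no measured step matches this change directly: the two steps that reach compound 3 exchange a ring-bearing group for hexyl, whereas here a chain merely grows longer and nothing else moves. Because those steps, a 2.4-fold lower number from compound 1 to compound 3 (0.38 log units; beyond the scatter) and a 3.3-fold lower number from compound 2 to compound 3 (0.52 log units; beyond the scatter), were only modest, the expected step of a 1.8-fold higher number from compound 3 to compound 4 (0.26 log units; within the scatter) is kept small and uncertain. Compound 4 is therefore estimated at 15 mg/kg in this assay, with a range from 6 mg/kg to 45 mg/kg.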

Compound 4, dose for half-maximal effect: > 100 mg/kg
Compound 4: a limit, no number (the forecaster's own chance of this, stated with the estimate: 15%); middle value at least 6.6-fold (0.82 log units) away from the limit.
By their numbers in this assay, from the lowest: compound 3; then compounds 1 and 2 (each within the scatter of the next). At a limit, above all of these: compound 4.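

For compound 4 the reading in this assay is a limit and not a number: the limit of > 100 mg/kg in this assay, at which 1 of the 4 values shown sits. Pentyl in place of hydrogen on a saturated chain carbon, seven bonds along the chain from an oxygen on an aromatic ring, gives an at least 12-fold higher number from compound 3 to compound 4 (1.08 log units; beyond the scatter), the only large step in this set. The earlier steps shown here, a 2.4-fold lower number from compound 1 to compound 3 (0.38 log units; beyond the scatter) and a 3.3-fold lower number from compound 2 to compound 3 (0.52 log units; beyond the scatter), were modest and exchanged a ring-bearing group for a plain chain, whereas this one shows that growing the chain alone, with nothing else changed, can move the number much further.

As far as these compounds go, whether a chain of intermediate length, such as nonyl, stays close to compound 3 or already behaves like compound 4 remains open. So does whether an amine or a carboxylic acid carried on the long chain would change this result.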